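From Phenyl to Ethyl in Compound 3

A few compounds are considered here, and "the series" means these few. Any claim that something is new, unique, unknown or untested is made for them only; others in the source may bear on it.

In an ADME assay on Caco-2 cells (Homo sapiens) for permeability (on this read-out higher numbers stand for higher permeability and lower numbers for lower permeability), compound 1 `COC(=O)c1ccc(/C=C/C(=O)N[C@@H]2O[C@H](CO)[C@@H](O)[C@H](O)[C@H]2O)cc1` gives 26.3 nm/s, and compound 2 `O=C(/C=C/c1ccc(-c2ccccc2)cc1)N[C@@H]1O[C@H](CO)[C@@H](O)[C@H](O)[C@H]1O` gives 80.2 nm/s, the higher of these two numbers. Compound 3 `CCc1ccc(/C=C/C(=O)N[C@@H]2O[C@H](CO)[C@@H](O)[C@H](O)[C@H]2O)cc1` has not yet been measured. Its structure departs from compound 2 by ethyl in place of phenyl on an aromatic carbon. Within the data shown here, only one measured step bears on this swap, the modest 3.0-fold higher number from compound 1 to compound 2 (0.48 log units; beyond the scatter), where phenyl replaced methoxycarbonyl. Ethyl itself is untested, so this is a rough guide, and a modest fall is expected: a 2.1-fold lower number from compound 2 to compound 3 (0.32 log units; beyond the scatter). For compound 3 the estimated value is 38 nm/s, within an expected range of 17 nm/s to 85 nm/s.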

Compound 3, apparent permeability in the Caco-2 assay: 94.7 nm/s
The estimate for compound 3 lay 2.5-fold (0.40 log units) below the measured number; the measured number lies above the stated range.
By their numbers in the Caco-2 assay, from the lowest: compound 1; then compounds 2 and 3 (each within the scatter of the next).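

In the Caco-2 assay, the step with ethyl in place of phenyl is a 1.2-fold higher number from compound 2 to compound 3 (0.07 log units; within the scatter), so the two groups cannot be told apart on this read-out, and a ring is not required at this place to reach that level. Ethyl in place of methoxycarbonyl gives a 3.6-fold higher number from compound 1 to compound 3 (0.56 log units; beyond the scatter), matching the gain seen with phenyl. In a physicochemical assay for lipophilicity, measured as octanol-water partition (a lower number here means a more polar compound, a higher number a more lipophilic compound), however, compound 2 gives 0.851 and compound 3 gives 0.04, so the two compounds do separate, with compound 3 the more polar: the measured partition coefficient of compound 2, 0.851, and of compound 3, 0.04, a number 0.81 log units lower (beyond the scatter)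

As far as these compounds go, whether a longer chain such as butyl would hold the same level remains open. So does the outcome with an amine or a carboxylic acid at this place.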